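The compounds below may be only part of what the source reports. "The series", "measured", "known", "first", "only" and "open" are said of these compounds alone.

In a functional assay on K562 cells (Homo sapiens) for antiproliferative activity, with a stated time of 72 h (on this read-out lower numbers stand for stronger inhibition and higher numbers for weaker inhibition), compound 2 `Cc1cccc(CNc2ncnc3c2ncn3[C@@H]2O[C@H](CO)[C@@H](O)[C@H]2O)c1` gives only a limit, > 166000 nM. Compound 1 `OC[C@H]1O[C@@H](n2cnc3c(NCc4ccccc4F)ncnc32)[C@H](O)[C@@H]1O` gives 33200 nM, and compound 3 `OC[C@H]1O[C@@H](n2cnc3c(NCc4ccc(F)c(Cl)c4)ncnc32)[C@H](O)[C@@H]1O` gives 5500 nM. Compound 2 therefore stands at the weak end of the three, with steps to both others beyond the scatter. Compound 4 `OC[C@H]1O[C@@H](n2cnc3c(NCc4cccc(OC(F)(F)F)c4)ncnc32)[C@H](O)[C@@H]1O` has not yet been measured. It departs from compound 2 by one change, trifluoromethoxy in place of methyl on an aromatic carbon. Going by the values given here, no measured step makes this exact swap. The closest replaces 3-methylphenyl with 3-chloro-4-fluorophenyl and gives an at least 30-fold lower number from compound 2 to compound 3 (1.47 log units; beyond the scatter). Starting from 2-fluorophenyl, the measured steps give an at least 5.0-fold higher number from compound 1 to compound 2 (0.69 log units; beyond the scatter) and a 6.0-fold lower number from compound 1 to compound 3 (0.78 log units; beyond the scatter). Changes to this aryl group have thus moved the number in both directions, and each step exceeded the scatter. A clear move to a lower number than the limit of compound 2 is expected in this assay, probably short of reaching compound 3. The expected change is an at least 5.5-fold lower number from compound 2 to compound 4 (0.74 log units; beyond the scatter). For compound 4 the estimated value is 30000 nM, within an expected range of 7000 nM to 130000 nM.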

Compound 4, half-maximal inhibitory concentration: > 166000 nM
Compound 4: no number, only a limit; the forecaster's own chance of this, stated with the estimate: 25%; at least 5.5-fold (0.74 log units) between middle value and limit.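

In this assay compound 4 gives > 166000 nM, a limit and not a number. Compound 2 sits at that same limit, so no step between the two can be read: the limit of > 166000 nM in this assay, at which 2 of the 4 values shown sit.

The compounds shown leave open whether trifluoromethoxy in place of methyl changes the read-out at all.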